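A Small Ring Swap at the Edge of Detection

This account rests on a few compounds, and the source may have more. Where it says the series, first, only, none or still open, it means among the compounds named here.

Of the compounds shown here, three on one shared core have been tested in a functional assay on A549 cells (Homo sapiens), read by MTT assay, with a stated time of 72 h; a lower number here means a stronger inhibitor, a higher number a weaker inhibitor. Compound 1 `COc1ncnc2c1c(-c1cccs1)cn2[C@@H]1O[C@H](CO)[C@@H](O)[C@H]1O` gives 4850 nM there. Compound 2 `CN(C)c1ncnc2c1c(-c1cc3ccccc3o1)cn2[C@@H]1O[C@H](CO)[C@@H](O)[C@H]1O` returns only a limit of the assay, > 20000 nM. Compound 3 `O=c1[nH]cnc2c1c(-c1ccsc1)cn2[C@@H]1O[C@H](CO)[C@@H](O)[C@H]1O` likewise returns only a limit, > 20000 nM. Compound 3 thus stands with compound 2 among the limit values, and two of the three results are of this kind (the limit of > 20000 nM in this assay, at which 2 of the 3 values shown sit). Compound 4 `O=c1[nH]cnc2c1c(-c1ccco1)cn2[C@@H]1O[C@H](CO)[C@@H](O)[C@H]1O` has not yet been measured in this assay; it differs from compound 3 by furan-2-yl in place of thiophen-3-yl on an aromatic carbon. For the measured compounds named here, no measured step of this kind exists among the three compounds. The expected step is a number no higher from compound 3 to compound 4 (the limit leaves the size open), within the scatter. Compound 4 is therefore expected to give about 20000 nM, within 7000 nM to 50000 nM, most likely again as a limit.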

Compound 4, half-maximal inhibitory concentration: > 20000 nM
Compound 4: only a limit was reported (the forecaster's own chance of this, stated with the estimate: 70%); the middle value lies on the limit itself.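

Compound 3 and compound 4 each return only a limit, so no step can be read between them: the limit of > 20000 nM in this assay, at which 3 of the 4 values shown sit. The compounds shown leave open whether furan-2-yl and thiophen-3-yl differ at all in this assay on the shared core.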